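The source may hold more compounds than are shown below. What is called first, only, known or untested is meant among the compounds shown, and "the series" means these compounds.

Measured compounds:
Compound 1 `O=C(NOCc1ccccc1Cl)c1cn(-c2ccccc2)nc1-c1ccccc1`; in an ADME assay on HEK-293T cells (Homo sapiens) for antiproliferative activity, read by MTT assay, with a stated time of 48 h, in the presence of a further agent that is not named here (a higher number here means that more compound is tolerated, a lower number that less compound is tolerated), compound 1 gives 82100 nM.
Compound 2 `Cc1ccc(-c2nn(-c3ccccc3)cc2C(=O)NOCc2ccccc2F)cc1`; in this assay compound 2 gives 20600 nM.

For the measured compounds named here, of these two numbers compound 2 stands lowest; compound 1 shows the higher number, a gap beyond the scatter, but the two differ in more than one place and no single step links them. Compound 3 `Cc1ccc(-c2nn(-c3ccccc3)cc2C(=O)NOCc2ccccc2Cl)cc1` is not yet measured. It differs from compound 2 by chloro in place of fluoro on an aromatic carbon. Going by the values given here, no step of this kind between measured compounds is available. The expected step is small, within the scatter, and in this assay the estimated shift is a 1.5-fold higher number from compound 2 to compound 3 (0.16 log units; within the scatter). Compound 3 is accordingly estimated at 30000 nM, with an expected range from 10000 nM to 90000 nM.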

Compound 3, half-maximal cytotoxic concentration: 38700 nM
Estimate against measurement, compound 3: 1.3-fold (0.11 log units) below; low and high end bracket the measured number.
By their numbers in this assay, from the lowest: compounds 2 and 3 (each within the scatter of the next); then compound 1.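

The series now has single-place steps in this assay. Chloro in place of fluoro on the benzyl ring gives a within-scatter change (from a 1.9-fold higher number from compound 2 to compound 3 (0.27 log units; within the scatter)), so the two halogens are not told apart at this aromatic carbon, whereas methyl in place of hydrogen on an aromatic carbon gives a modest change (from a 2.1-fold lower number from compound 1 to compound 3 (0.33 log units; beyond the scatter)), the only one of the two steps beyond the scatter. No measured property bears on either step.

Open, on these data alone, is whether a methoxy group, a nitrile or an amine in place of the chloro would shift the number beyond the scatter. Also open, as far as these compounds go, is whether the methyl step holds with fluoro in place of chloro.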